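A few compounds are considered here, and "the series" means these few. Any claim that something is new, unique, unknown or untested is made for them only; others in the source may bear on it.

Compound 2 `O=C(NC(=S)Nc1ccc(Cl)cc1)c1cn(-c2ccccc2)nc1-c1ccc(Cl)cc1` gives 3150 nM in a functional assay on A549 cells (Homo sapiens) for inhibition, read by CCK-8 assay, with a stated time of 48 h; a lower number here means a stronger inhibitor, a higher number a weaker inhibitor. Compound 1 `Cc1ccc(NC(=S)NC(=O)c2cn(-c3ccccc3)nc2-c2ccc(Cl)cc2)cc1` carries a methyl where compound 2 carries a chloro, and in this assay compound 1 gives 2690 nM. Compound 3 `O=C(NC(=S)Nc1ccc(F)cc1)c1cn(-c2ccccc2)nc1-c1ccc(Cl)cc1`, with a fluoro in that same place, gives 3980 nM. Compound 2 stands close to both: a 1.2-fold higher number from compound 1 to compound 2 (0.07 log units; within the scatter), a 1.3-fold higher number from compound 2 to compound 3 (0.10 log units; within the scatter), and likewise a 1.5-fold higher number from compound 1 to compound 3 (0.17 log units; within the scatter), so the three numbers cannot be told apart.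

Compound 4 `O=C(NC(=S)Nc1ccc(Cl)cc1)c1cn(-c2ccccc2)nc1-c1ccccc1` differs from compound 2 by hydrogen in place of chloro on an aromatic carbon. For the measured compounds named here, this change sits on the 4-chlorophenyl group of the shared core, not on the ring where compounds 1, 2 and 3 differ, so no measured pair tests exactly this spot. Going by the values given here, the three steps that do exist all swap small groups on an aromatic carbon, and none moved this assay beyond the scatter, which is the only guide available. Compound 4 is therefore expected to give 4000 nM, in the range 1800 nM to 9000 nM. The expected step is a 1.3-fold higher number from compound 2 to compound 4 (0.10 log units; within the scatter), that is, no change beyond the scatter, with a mild loss judged somewhat more likely than a gain.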

Compound 4, half-maximal inhibitory concentration: 3200 nM
The estimate for compound 4 lay 1.3-fold (0.10 log units) above the measured number; the range from low to high includes it.
By their numbers in this assay, from the lowest: compounds 1, 2, 4 and 3 (each within the scatter of the next).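

The change from 4-chlorophenyl to phenyl on the shared core comes with a 1.0-fold higher number from compound 2 to compound 4 (0.01 log units; within the scatter) in this assay, so removing this chloro leaves the number within the scatter. For the compounds shown here, compounds 1, 2 and 3 differ only on another aromatic ring, so this pair is the first direct test of this position, and it shows that hydrogen and chloro here cannot be told apart in this assay. This reading rests on a single pair, and nothing given here explains the result.

At this position, the compounds shown compare only chloro and hydrogen, so it remains open whether an amine, a methoxy group or a carboxylic acid would also stay within the scatter. As far as these compounds go, it is also open whether removing this chloro would give the same result alongside the methyl of compound 1 or the fluoro of compound 3.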